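The source may report more compounds than this note shows. Statements on the series, on what has been measured and on what is new or still open speak of the compounds shown alone.

Working notes on the series. Two compounds of this core have been run in a functional assay on PC-3 cells (Homo sapiens) for cytotoxicity, read by MTT assay, with a stated time of 72 h (on this read-out lower numbers stand for stronger inhibition and higher numbers for weaker inhibition), so far. Compound 1 `O=C(Nc1nc2ccccc2s1)c1cn(-c2ccccc2)nc1-c1ccc(F)cc1` gives 7130 nM in this assay. Compound 2 `O=C(Nc1nc2ccc(Cl)cc2s1)c1cn(-c2ccccc2)nc1-c1ccc(F)cc1` gives 3170 nM in this assay. Among the compounds with values here, the single step between them, a 2.2-fold lower number from compound 1 to compound 2 (0.35 log units; beyond the scatter), puts compound 2 at the lower of the two numbers, and compound 1 sits a step above it that is beyond the scatter.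

Compound 3 `Cc1ccc2nc(NC(=O)c3cn(-c4ccccc4)nc3-c3ccc(F)cc3)sc2c1` is the next member and is not yet measured in this assay. It differs from compound 2 in one place: methyl in place of chloro on an aromatic carbon, read one bond further out as 6-chloro-1,3-benzothiazol-2-yl becoming 6-methyl-1,3-benzothiazol-2-yl. Within the data shown here, no measured step bears on this exchange directly; the only step in hand, a 2.2-fold lower number from compound 1 to compound 2 (0.35 log units; beyond the scatter), concerns the same aromatic carbon but compares chloro with hydrogen, and it was modest. The expectation for compound 3 is therefore a step within or near the scatter, a 1.4-fold higher number from compound 2 to compound 3 (0.15 log units; within the scatter), most likely toward a somewhat higher number. The estimate for compound 3 in this assay is 4500 nM, with a range from 2000 nM to 10000 nM.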

Compound 3, half-maximal inhibitory concentration: 20500 nM
For compound 3 the middle estimate is 4.6-fold (0.66 log units) below the measured one, outside the stated range (above it).
By their numbers in this assay, from the lowest: compound 2; then compound 1; then compound 3.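

In this assay, 6-chloro-1,3-benzothiazol-2-yl becoming 6-methyl-1,3-benzothiazol-2-yl gives a 6.5-fold higher number from compound 2 to compound 3 (0.81 log units; beyond the scatter), so this aromatic carbon responds more strongly to what it carries than the chloro-for-hydrogen comparison alone could show. Methyl in place of hydrogen on the same carbon gives a 2.9-fold higher number from compound 1 to compound 3 (0.46 log units; beyond the scatter), opposite in direction to a 2.2-fold lower number from compound 1 to compound 2 (0.35 log units; beyond the scatter), which places the unsubstituted compound 1 between the two substituted compounds, with each step beyond the scatter. No measurement in hand accounts for chloro and methyl, each a single heavy atom, moving the number in opposite directions.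

These three compounds cannot show whether a bromo, methoxy or trifluoromethyl group on this carbon would fall on the side of chloro or of methyl, so no ranking of groups at this position can be drawn beyond the three in hand. They also leave open whether the order seen here would persist with a change elsewhere on the shared core, such as an amine in place of the fluoro group.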